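A few compounds are considered here, and "the series" means these few. Any claim that something is new, unique, unknown or untested is made for them only; others in the source may bear on it.

Working notes on the series. The shared core is carried by compound 1 `C#CCOCN1C(=O)c2ccccc2NS1(=O)=O`, compound 2 `CCCOCN1c2ccccc2C(=O)NS1(=O)=O` and compound 3 `C#CCOCN1c2ccccc2C(=O)N(Cc2ccccc2)S1(=O)=O`; compound 4 `CC(=O)OCCOCN1c2ccccc2C(=O)NS1(=O)=O` is the next member, not yet measured. In a functional assay on HEL cells (Homo sapiens) for cytotoxicity (on this read-out higher numbers stand for lower toxicity in this test and lower numbers for higher toxicity in this test), compound 3 gives 50 ug/mL. For compound 1 the read-out in this assay is a limit of the test, > 50 ug/mL, and not a number. For compound 2 the read-out in this assay is likewise a limit, > 50 ug/mL. Compound 2 thus stands at the limit of > 50 ug/mL in this assay, at which 2 of the 3 values shown sit, so its place relative to the other members cannot be ordered from the numbers shown. Among the measured compounds shown here, no pair of measured compounds differing in a single place is available, so no measured step exists for reference.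

Compound 4 differs from compound 2 as follows: acetoxy in place of methyl on a saturated chain carbon, two bonds along the chain from an oxygen on a saturated carbon. The measured set contains nothing that shows how a change of this kind moves the read-out in this assay. The step from compound 2 to compound 4 is expected to be a step that the limit leaves unreadable from compound 2 to compound 4, that is, no change beyond the usual scatter in either direction. Compound 4 is therefore expected to give about 60 ug/mL in this assay, within a range from 35 ug/mL to 150 ug/mL, and most probably to be reported again only as a limit.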

Compound 4, minimum cytotoxic concentration: > 50 ug/mL
Compound 4 gave a limit, no number; the forecaster's own chance of this, stated with the estimate: 75%; the middle value does not contradict the limit.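

Compound 2 and compound 4 both stand only as limits in this assay, so no step from compound 2 to compound 4 can be read: the limit of > 50 ug/mL in this assay, at which 3 of the 4 values shown sit.

The compounds shown leave open whether acetoxy in place of methyl at this place on the chain moves the read-out at all, and in which direction.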